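This account rests on a few compounds, and the source may have more. Where it says the series, first, only, none or still open, it means among the compounds named here.

Among the three compounds measured in an ADME assay for pharmacokinetics, read by HPLC, in phosphate buffer, with a stated time of 72 h, at pH 7.4, tested at 250 uM (a higher number here means that the compound lasts longer, a lower number that the compound disappears faster), compound 3 `FC(F)(F)c1cc(C2CO2)cc(C(F)(F)F)c1` stands at the top. Compound 3 gives > 50 h, which is a limit of the assay rather than a number. Compound 1 `C#Cc1cc(C(F)(F)F)cc(C(F)(F)F)c1` gives 2.4 h. Compound 2 `O=C(CBr)c1cc(C(F)(F)F)cc(C(F)(F)F)c1` gives < 0.017 h, again a limit of the assay. Compound 4 `FC(F)(F)c1cc(S)cc(C(F)(F)F)c1` differs from compound 3 by sulfanyl in place of oxiran-2-yl on an aromatic carbon. Every measured step also swaps the group on that same aromatic carbon, and each was large: an at least 140-fold lower number from compound 1 to compound 2 (2.14 log units; beyond the scatter), an at least 20-fold higher number from compound 1 to compound 3 (1.31 log units; beyond the scatter) and an at least 2900-fold higher number from compound 2 to compound 3 (3.46 log units; beyond the scatter). A large step is therefore expected here too, and since compound 3 already sits at a limit, the expected direction is downward, an at least 10-fold lower number from compound 3 to compound 4 (1.00 log units; beyond the scatter). Compound 4 is expected to give 5 h, within a range from 0.5 h to 50 h.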

Compound 4, half-life: > 50 h
Compound 4: a limit, no number; the forecaster's own chance of this, stated with the estimate: 25%; middle value at least 10-fold (1.00 log units) away from the limit.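

Sulfanyl, a single sulfur atom with no ring, joins oxiran-2-yl at the upper limit of this assay, so the three-membered ring is not required on this aromatic carbon for a compound to reach that limit. Both readable steps are large: an at least 2900-fold higher number from compound 2 to compound 4 (3.46 log units; beyond the scatter) and an at least 20-fold higher number from compound 1 to compound 4 (1.31 log units; beyond the scatter). The step between compound 3 and compound 4 cannot be read, because both sit at the same limit: the limit of > 50 h in this assay, at which 2 of the 4 values shown sit.

As far as these compounds go, how long either compound actually lasts stays open. So does whether an amine or a carboxylic acid on this carbon would also reach that limit.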